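The source may report more compounds than this note shows. Statements on the series, on what has been measured and on what is new or still open speak of the compounds shown alone.

Compound 1 `CCOC(=O)c1nn(-c2ccc(C(C)(C)C)cc2)c(=O)c2c(N)scc12` gives 9750 nM in an assay on CHO-K1 cells with adenosine receptor A1 (Homo sapiens) as the target; on this read-out lower numbers stand for an effect already at smaller amounts and higher numbers for an effect only at larger amounts of compound.
Compound 2 `CCOC(=O)c1nn(-c2cccc(C(F)(F)F)c2)c(=O)c2c(N)scc12` gives 2700 nM in this assay.
Compound 3 `CCOC(=O)c1nn(-c2ccc(C(F)(F)F)cc2)c(=O)c2c(N)scc12` gives 8400 nM in this assay.

Among these three numbers, compound 3 stands second highest; compound 1 lies nearest to it, within the scatter, while compound 2 lies furthest, beyond it. Compound 4 `CCOC(=O)c1nn(-c2ccc(OC(C)=O)cc2)c(=O)c2c(N)scc12` differs from compound 3 by acetoxy in place of trifluoromethyl on an aromatic carbon. Going by the values given here, the only measured step at this place, a 1.2-fold lower number from compound 1 to compound 3 (0.06 log units; within the scatter), moved nothing beyond the scatter, and no measured step involves an acetoxy group. On that basis a change in this assay of no more than the scatter is expected, with no preferred direction. Compound 4 is therefore expected to give about 7500 nM (range 2500 nM to 22000 nM) in this assay, which amounts to an expected 1.1-fold lower number from compound 3 to compound 4 (0.05 log units; within the scatter).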

Compound 4, half-maximal effective concentration: 2500 nM
For compound 4 the middle estimate is 3.0-fold (0.48 log units) above the measured one; measured number inside the range.
By their numbers in this assay, from the lowest: compounds 4 and 2 (each within the scatter of the next); then compounds 3 and 1 (each within the scatter of the next).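

The aromatic carbon para to a large group proves responsive after all: tert-butyl and trifluoromethyl could not be told apart there, but acetoxy gives a 3.4-fold lower number from compound 3 to compound 4 (0.53 log units; beyond the scatter) and a 3.9-fold lower number from compound 1 to compound 4 (0.59 log units; beyond the scatter) in this assay. Both steps are modest, yet they set acetoxy apart from the other two groups at this place. Nothing available explains this shift. Going by these compounds, it remains open whether an amine, a carboxylic acid or a longer ester chain at this carbon would move the number further. Also open, on these data alone, is how acetoxy would behave at the ring carbon bearing trifluoromethyl in compound 2.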